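Chloro in Place of Fluoro at an Assay Limit

The source may hold more compounds than are shown below. What is called first, only, known or untested is meant among the compounds shown, and "the series" means these compounds.

In a functional assay on HT-29 cells (Homo sapiens) for antiproliferative activity, read by sulforhodamine B assay, with a stated time of 48 h (on this read-out higher numbers stand for weaker inhibition and lower numbers for stronger inhibition), compound 1 (`COc1cccc(OS(=O)(=O)c2ccc(N3CCN(C)C3=O)cc2)c1`) gives 2500 nM. Compound 2 (`CN1CCN(c2ccc(S(=O)(=O)Oc3cccc(F)c3)cc2)C1=O`) reads > 100000 nM, which is a limit of the assay and not a number. For the measured compounds named here, the one measured step, an at least 40-fold higher number from compound 1 to compound 2 (1.60 log units; beyond the scatter), is large and puts fluoro in place of methoxy on an aromatic carbon. Compound 3 (`CN1CCN(c2ccc(S(=O)(=O)Oc3cccc(Cl)c3)cc2)C1=O`) differs from compound 2 by chloro in place of fluoro on an aromatic carbon, at that same place. Given the size of an at least 40-fold higher number from compound 1 to compound 2 (1.60 log units; beyond the scatter), a moderate move towards stronger inhibition in this assay is expected, though it remains uncertain. The expected step is an at least 5.0-fold lower number from compound 2 to compound 3 (0.69 log units; beyond the scatter). The estimated value for compound 3 is 20000 nM, within a range of 3000 nM to 100000 nM.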

Compound 3, half-maximal inhibitory concentration: 2100 nM
The estimate for compound 3 lay 9.5-fold (0.98 log units) above the measured number, and the stated range ends above it.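

Chloro in place of fluoro at this place recovers the activity in this assay, with an at least 47-fold lower number from compound 2 to compound 3 (1.67 log units; beyond the scatter). Chloro and methoxy cannot be told apart here, with a 1.2-fold lower number from compound 1 to compound 3 (0.08 log units; within the scatter), so among these three compounds only the fluoro compound stands apart. The first step has no exact size because compound 2 sits at a limit of the assay, which is not a number: the limit of > 100000 nM in this assay, at which 1 of the 3 values shown sits.

The compounds shown leave open how a methyl group, a bromo group or an amine would read at this place. They also leave open whether chloro in place of fluoro has a similar effect elsewhere on this ring.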